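The compounds below may be only part of what the source reports. "The series", "measured", "known", "first", "only" and "open" are said of these compounds alone.

Compound 2 `Cn1cnc2cc3c(cc21)C1CNCC3C1` holds the highest number of the two compounds measured in an assay on HEK293 cells for binding affinity to Neuronal acetylcholine receptor; alpha4/beta2 (Homo sapiens) (a higher number here means a weaker inhibitor, a lower number a stronger inhibitor), where compound 2 gives 0.75 nM. Among the compounds with values here, its only neighbour, compound 1 `CC(C)Cn1cnc2cc3c(cc21)C1CNCC3C1`, gives 0.3 nM in this assay, and the change a 2.5-fold higher number from compound 1 to compound 2 (0.40 log units; beyond the scatter). Compound 3 `CCCCn1cnc2cc3c(cc21)C1CNCC3C1` differs from compound 2 by propyl in place of hydrogen on a saturated chain carbon bound to an aromatic nitrogen. Within the data shown here, the single step that bears on this, from compound 1 to compound 2, ran the other way and was modest, so a modest lowering of the number is expected for compound 3, while a straight chain itself is untested here. Compound 3 is therefore estimated at 0.35 nM, within 0.15 nM to 0.9 nM, an expected step of a 2.1-fold lower number from compound 2 to compound 3 (0.33 log units; beyond the scatter).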

Compound 3, inhibition constant: 0.2 nM
The estimate for compound 3 lay 1.8-fold (0.24 log units) above the measured number; measured number inside the range.
By their numbers in this assay, from the lowest: compounds 3 and 1 (each within the scatter of the next); then compound 2.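

In this assay propyl in place of hydrogen on a saturated chain carbon bound to an aromatic nitrogen gives a 3.8-fold lower number from compound 2 to compound 3 (0.57 log units; beyond the scatter) and so shows that a straight chain lowers the number here, as the branched chain of compound 1 did. Propyl in place of isopropyl gives a 1.5-fold lower number from compound 1 to compound 3 (0.18 log units; within the scatter) and so does not separate the straight chain from the branched one at this position. No measurement shown accounts for either step. Still open, from the compounds shown here alone, is whether a longer chain keeps the number this low, and whether a chain ending in an amine or a carboxylic acid does the same.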